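Aryl swap on the shared core: from compound 1 to compound 3

This account rests on a few compounds, and the source may have more. Where it says the series, first, only, none or still open, it means among the compounds named here.

Measured so far:
compound 1 `C=CCn1c(=O)/c(=C\c2ccccc2Cl)[nH]c(=O)/c1=C\c1ccccc1OC` — 4700 nM
compound 2 `C=CCn1c(=O)/c(=C\c2cccc(Br)c2)[nH]c(=O)/c1=C\c1cccc(Br)c1` — "not active" (no number reported)

In a functional assay on MCF7 cells (Homo sapiens) for cytotoxicity, read by CCK-8 assay, with a stated time of 72 h (on this read-out lower numbers stand for stronger inhibition and higher numbers for weaker inhibition), compound 1 gives 4700 nM. Compound 2 is recorded in this assay as "not active" (no number reported), with no number attached, so it cannot be ranked against compound 1. Going by the values given here, compound 1 therefore holds the only numerical value in this set.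

Compound 3 `C=CCn1c(=O)/c(=C\c2cc(F)ccc2C)[nH]c(=O)/c1=C\c1ccccc1OC` has not yet been measured. It differs from compound 1 in one place: 5-fluoro-2-methylphenyl in place of 2-chlorophenyl on a double-bonded chain carbon bound to an aromatic carbon. Among the compounds with values here, no measured pair shows a single change of this kind, so the size of the step cannot be read off from the data; one aryl group is exchanged for another of similar make-up, and the expected step of a 1.1-fold higher number from compound 1 to compound 3 (0.03 log units; within the scatter) is small, essentially none beyond the usual scatter, with the outcome of compound 2 a reminder that loss of activity is possible. For compound 3 in this assay the estimate is 5000 nM, expected to lie between 1500 nM and 17000 nM.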

Compound 3, half-maximal inhibitory concentration: 3100 nM
For compound 3 the middle estimate is 1.6-fold (0.21 log units) above the measured one, within the range that was stated.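

In this assay, going by these compounds alone, 5-fluoro-2-methylphenyl in place of 2-chlorophenyl on a double-bonded chain carbon bound to an aromatic carbon gives a 1.5-fold lower number from compound 1 to compound 3 (0.18 log units; within the scatter), the first single-place step. This place therefore accepts this exchange of one substituted phenyl for another, and activity is kept with the chlorine gone and a fluorine and a methyl present. No measured property bears on this result, so the step stands without an explanation.

This single step does not separate the fluorine from the methyl, and the rest of the shared core is the same in compound 1 and compound 3, so its contribution stays unread. As far as these compounds go, whether this place would also accept a phenyl carrying an amine or a carboxylic acid remains open.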